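A few compounds are considered here, and "the series" means these few. Any claim that something is new, unique, unknown or untested is made for them only; others in the source may bear on it.

Series notes: in a functional assay on RAW264.7 cells (Mus musculus) for inhibition, read by Griess assay, with stated times of 1 h and 24 h (on this read-out lower numbers stand for stronger inhibition and higher numbers for weaker inhibition), compound 1 `CC(C)COc1ccccc1C1CC(=O)c2ccccc2O1` gives 36700 nM, compound 2 `CCCCOc1ccccc1C1CC(=O)c2ccccc2O1` gives 48700 nM, and compound 3 `O=C1CC(c2ccccc2OCc2ccccc2)Oc2ccccc21` gives 18900 nM. Compound 3 cannot be separated from compound 1, with a 1.9-fold lower number from compound 1 to compound 3 (0.29 log units; within the scatter), but a 2.6-fold lower number from compound 2 to compound 3 (0.41 log units; beyond the scatter) is a modest step beyond the scatter. The step of a 1.3-fold higher number from compound 1 to compound 2 (0.12 log units; within the scatter) also leaves the two alkyl chains unresolved. Compound 4 `CCOc1ccccc1C1CC(=O)c2ccccc2O1` has methyl in place of phenyl on a saturated chain carbon bound to an oxygen on an aromatic ring. Removing the phenyl is expected to partly reverse the step seen with compound 2, a 2.6-fold lower number from compound 2 to compound 3 (0.41 log units; beyond the scatter), and a modest move to a higher number is anticipated. The expected change is a 2.4-fold higher number from compound 3 to compound 4 (0.38 log units; beyond the scatter). The estimate for compound 4 is 45000 nM, with an expected range of 22000 nM to 90000 nM.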

Compound 4, half-maximal inhibitory concentration: 38500 nM
Estimate against measurement, compound 4: 1.2-fold (0.07 log units) above; the range from low to high includes it.
By their numbers in this assay, from the lowest: compounds 3, 1, 4 and 2 (each within the scatter of the next, the first and the last beyond it).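

With a 2.0-fold higher number from compound 3 to compound 4 (0.31 log units; beyond the scatter), benzyloxy now separates from ethoxy as well as from the butyl ether of compound 2, although compound 1 goes against a clean split, staying within the scatter of compound 3. Ethoxy cannot be resolved from the larger alkyl ethers, with a 1.3-fold lower number from compound 2 to compound 4 (0.10 log units; within the scatter) and a 1.0-fold higher number from compound 1 to compound 4 (0.02 log units; within the scatter), so changing the alkyl group alone shows no readable effect here. No evidence explaining the separation of the benzyloxy compound is available. Open, from the compounds shown here alone, is whether an amine or a carboxylic acid on this chain would move the number. Also open, going by these compounds, is whether a pyridine in place of the phenyl would keep the position of compound 3.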